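Shortening a Chain: What to Expect for Compound 4

The source may report more compounds than this note shows. Statements on the series, on what has been measured and on what is new or still open speak of the compounds shown alone.

Of the compounds shown here, three have been measured in a functional assay on SK-N-SH cells (Homo sapiens) for inhibition, read by MTT assay; on this read-out lower numbers stand for stronger inhibition and higher numbers for weaker inhibition. Compound 1 `CCCCCCCCn1cc(/C=C/C(=O)c2ccc(NC(=O)CN3CCN(C(=O)OC(C)(C)C)CC3)cc2)nn1` gives 38000 nM, compound 3 `CCCCCCCCCCn1cc(/C=C/C(=O)c2ccc(NC(=O)CN3CCN(C(=O)OC(C)(C)C)CC3)cc2)nn1` gives 77800 nM, and compound 2 `CCCCCCCCCCn1cc(/C=C/C(=O)c2ccc(NC(=O)CN3CCC(Cc4ccccc4)CC3)cc2)nn1` gives 33300 nM. Compound 1 and compound 3 differ in a single place, (hydrogen in place of ethyl on a saturated chain carbon, eight bonds along the chain from an aromatic nitrogen), and that change produced the step of a 2.0-fold lower number from compound 3 to compound 1 (0.31 log units; beyond the scatter). Compound 4 `CCCCCCCCn1cc(/C=C/C(=O)c2ccc(NC(=O)CN3CCC(Cc4ccccc4)CC3)cc2)nn1` has not yet been measured; it carries the same change relative to compound 2, (hydrogen in place of ethyl on a saturated chain carbon, eight bonds along the chain from an aromatic nitrogen), at a place described in the same words. The difference between the core of compound 2 and the core of compound 3 is not broken down here. Among the measured compounds shown here, the step from compound 2 to compound 4 in this assay is expected to be a 1.7-fold lower number from compound 2 to compound 4 (0.22 log units; within the scatter), resting on the single earlier step of a 2.0-fold lower number from compound 3 to compound 1 (0.31 log units; beyond the scatter). Compound 4 is therefore estimated at 20000 nM, with a likely range from 8000 nM to 50000 nM.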

Compound 4, half-maximal inhibitory concentration: 57000 nM
Beside the measured number, compound 4's estimate is 2.9-fold (0.45 log units) below it; measured number above the stated range.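

Measured in this assay, putting hydrogen in place of ethyl on this chain gives a 1.7-fold higher number from compound 2 to compound 4 (0.23 log units; within the scatter), so this pair alone cannot be told apart from repeat-measurement noise. Set beside the earlier pair, the change does not carry over as a fixed step from one core to the other: the same change on two cores in this assay, a 2.0-fold lower number (0.31 log units; beyond the scatter) from compound 3 to compound 1 and a 1.7-fold higher number (0.23 log units; within the scatter) from compound 2 to compound 4, 3.5-fold (0.54 log units) apart, beyond the scatter of two such steps With only two pairs, this does not show which feature of the cores sets the gap, nor how the change would behave on any other core.

From the compounds shown here alone, what a carboxylic acid or an amine on this chain would do on either core remains open. Also open, going by these compounds, is which of these two pairs a third core would resemble.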